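A Diethylaminoethyl Chain Replaces the Hydrazone Arm

The source may hold more compounds than are shown below. What is called first, only, known or untested is meant among the compounds shown, and "the series" means these compounds.

Compound 2 `COc1cc(OC)c2c(=O)c(OCC(=O)N/N=C/c3ccc[nH]3)c(-c3cc(OC)c(OC)c(OC)c3)oc2c1` and compound 1 `COc1cc(OC)c2c(=O)c(OCC(=O)N/N=C/c3sccc3C)c(-c3cc(OC)c(OC)c(OC)c3)oc2c1` share a common core. In a functional assay on SGC-7901 cells (Homo sapiens) for cytotoxicity, read by MTT assay, with a stated time of 38 h (a lower number here means a stronger inhibitor, a higher number a weaker inhibitor), compound 1 gives 10300 nM, while compound 2 gives 8730 nM. The only measured step, a 1.2-fold lower number from compound 1 to compound 2 (0.07 log units; within the scatter), is within the scatter, so on the two numbers shown compound 2 stands beside compound 1, neither stronger nor weaker.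

Compound 3 `CCN(CC)CCCOc1c(-c2cc(OC)c(OC)c(OC)c2)oc2cc(OC)cc(OC)c2c1=O` differs from compound 2 at one place: a group of 7 heavy atoms (6 carbon, 1 nitrogen; no ring) in place of a group of 10 heavy atoms (6 carbon, 3 nitrogen, 1 oxygen; one five-membered aromatic ring with 1 hetero atom), on a saturated chain carbon bound to an oxygen on an aromatic ring. Among the measured compounds shown here, no measured step bears on this change; the one step recorded swapped one five-membered aromatic ring for another on the same arm and barely moved the number, whereas here the entire arm leaves and a chain enters. The step in this assay therefore cannot be anchored in size or direction. Compound 3 is expected to give about 7000 nM, within 1500 nM to 30000 nM. The expected step of a 1.2-fold lower number from compound 2 to compound 3 (0.10 log units; within the scatter) is small, but carries wide uncertainty.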

Compound 3, half-maximal inhibitory concentration: 56900 nM
Compound 3: the middle estimate sits 8.1-fold (0.91 log units) below what was measured, and the stated range ends below it.
By their numbers in this assay, from the lowest: compounds 2 and 1 (each within the scatter of the next); then compound 3.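

Swapping one five-membered aromatic ring for another on the hydrazone arm left the number within the scatter, but replacing the whole arm with 2-(diethylamino)ethyl, on a saturated chain carbon bound to an oxygen on an aromatic ring, does register in this assay (a 6.5-fold higher number from compound 2 to compound 3 (0.81 log units; beyond the scatter); a 5.5-fold higher number from compound 1 to compound 3 (0.74 log units; beyond the scatter)). Both steps run the same way, so compound 1 and compound 2 stand on the same side of compound 3, and in these three compounds the change of arm counts for more than the change of ring at its end. Nothing measured here accounts for the higher number.

The compounds shown do not separate the loss of the hydrazone arm from the entry of the diethylamino group, as both happen in one step. On these data alone, how a longer chain, a morpholine or a carboxylic acid at this place would compare also stays open.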